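Aryl Amide Variation in Sulfonamide Receptor Agonists

The source may report more compounds than this note shows. Statements on the series, on what has been measured and on what is new or still open speak of the compounds shown alone.

compound 1 `O=C(Nc1ccc(S(=O)(=O)Nc2cccc(Cl)c2)cc1)c1ccc(Cl)cc1Cl`: 575 nM
compound 2 `O=S(=O)(Nc1ccccc1)c1ccc(NS(=O)(=O)c2ccc(Cl)cc2Cl)cc1`: > 100000 nM
compound 3 `Cc1cc(Cl)ccc1C(=O)Nc1ccc(S(=O)(=O)Nc2ccccc2)cc1`: 912 nM

In a functional assay on HEK293 cells for agonist activity at probable G-protein coupled receptor 27 (Homo sapiens), read by a luciferase reporter and beta-arrestin recruitment, with a stated time of 10 min (a higher number here means that more compound is needed for the effect, a lower number that less compound is needed), compound 3 gives 912 nM, the highest of the two numbers shown, and its nearest neighbour compound 1 gives 575 nM, a gap that lies within the scatter. Compound 2 reaches only the limit of > 100000 nM and yields no number (the limit of > 100000 nM in this assay, at which 1 of the 3 values shown sits). Compound 4 `O=C(Nc1ccc(S(=O)(=O)Nc2ccccc2)cc1)c1ccc(Br)cc1F` has not yet been measured; it differs from compound 3 by 4-bromo-2-fluorophenyl in place of 4-chloro-2-methylphenyl on a carbonyl carbon. Among the measured compounds shown here, no step between measured compounds covers this change, and the amide linkage is kept, so any step in this assay is expected to stay within the scatter, in no fixed direction. Compound 4 is therefore estimated at 800 nM, between 250 nM and 2500 nM, the step of a 1.1-fold lower number from compound 3 to compound 4 (0.06 log units; within the scatter) being expected to be small.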

Compound 4, half-maximal effective concentration: 479 nM
For compound 4 the middle estimate is 1.7-fold (0.22 log units) above the measured one; low and high end bracket the measured number.
By their numbers in this assay, from the lowest: compounds 4, 1 and 3 (each within the scatter of the next). At a limit, above all of these: compound 2.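

In this assay, among the compounds shown here, the exchange of 4-chloro-2-methylphenyl for 4-bromo-2-fluorophenyl on a carbonyl carbon gives a 1.9-fold lower number from compound 3 to compound 4 (0.28 log units; within the scatter) as the first step that can be read at this place. With the amide linkage kept, two differently substituted aryl groups are thus accepted here without a step beyond the scatter. Nothing measured here gives a cause for this step.

The compounds shown leave open whether this tolerance extends to an amine or a carboxylic acid on the aryl group. They also do not show what an alkyl chain in place of the aryl group would give.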